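Epimer of compound 2 at one ring carbon

The compounds below may be only part of what the source reports. "The series", "measured", "known", "first", "only" and "open" are said of these compounds alone.

Compound 1 `CC1=CC[C@@]2(O)[C@H](C)CC[C@@H](C(C)C)[C@@H]2C1=O` reaches only the limit of a functional assay on MCF7 cells (Homo sapiens) for cytotoxicity, read by MTT assay (a higher number here means a weaker inhibitor, a lower number a stronger inhibitor), giving > 10 ug/mL. Compound 2 `CC1=CC[C@]2(O)[C@@H]([C@@H]1O)[C@H](C(C)C)CC[C@H]2C` likewise reaches only a limit in this assay, giving > 10 ug/mL. This is what the evidence shows: the limit of > 10 ug/mL in this assay, at which 2 of the 2 values shown sit. Within the data shown here, compound 3 `CC1=CC[C@]2(O)[C@@H]([C@H]1O)[C@H](C(C)C)CC[C@H]2C` is not yet measured. the two compounds have the same atoms and bonds and differ only in configuration as drawn: 1 of 5 stereo elements differ; a stereocentre at a saturated ring carbon is drawn S in compound 2 and R in compound 3 No measured step of this kind exists, and with the values shown all at the limit, the expected step in this assay a step that the limit leaves unreadable from compound 2 to compound 3 is none beyond the scatter, in no particular direction. Compound 3 is therefore estimated at 15 ug/mL, with a range from 7 ug/mL to 40 ug/mL, most likely again reported only as a limit.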

Compound 3, half-maximal inhibitory concentration: > 10 ug/mL
Compound 3 was reported as a limit; the forecaster's own chance of this, stated with the estimate: 75%; the middle value does not contradict the limit.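

Among these compounds, no step from compound 2 to compound 3 can be read, since both values are limits in this assay: the limit of > 10 ug/mL in this assay, at which 3 of the 3 values shown sit. Left open is whether the configuration at that saturated ring carbon matters at all in this assay.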